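The source may hold more compounds than are shown below. What is called first, only, known or untested is meant among the compounds shown, and "the series" means these compounds.

Measured compounds in the series:

Compound 1 `COc1ncc(-c2ccc3c(c2)N(c2ccccc2)C(=O)CO3)cc1NS(=O)(=O)c1ccc(F)cc1`: 1530 nM
Compound 2 `O=C1COc2ccc(-c3cccc(NS(=O)(=O)c4ccc(F)cc4)c3)cc2N1c1ccccc1`: 17700 nM
Compound 3 `COc1ncc(-c2ccc3c(c2)N(C2CC2)C(=O)CO3)cc1NS(=O)(=O)c1ccc(F)cc1`: 6030 nM

Read-out throughout is a functional assay on HeLa cells (Homo sapiens) for antiproliferative activity, read by MTT assay, with a stated time of 72 h; on this read-out higher numbers stand for weaker inhibition and lower numbers for stronger inhibition. Compound 1 gives the lowest of the three numbers; compound 2 stands highest, with compound 3 between them. The difference between the core of compound 1 and the core of compound 2 is not broken down here.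

One change recurs. From compound 1 to compound 3 it is cyclopropyl in place of phenyl on an amide-type nitrogen in a ring, and it moved the number by a 3.9-fold higher number from compound 1 to compound 3 (0.60 log units; beyond the scatter). The same change, (cyclopropyl in place of phenyl on an amide-type nitrogen in a ring), leads from compound 2 to the unmeasured compound 4 `O=C1COc2ccc(-c3cccc(NS(=O)(=O)c4ccc(F)cc4)c3)cc2N1C1CC1`; the place is the same in both pairs, word for word, so this is counted as the same change.

Within the data shown here, for compound 4 in this assay the step is expected to be about a 3.4-fold higher number from compound 2 to compound 4 (0.53 log units; beyond the scatter), resting on the single earlier pair, because the step of a 3.9-fold higher number from compound 1 to compound 3 (0.60 log units; beyond the scatter) is the only measured precedent; with one precedent the width is left generous. Compound 4 is thus estimated at 60000 nM, in the range 25000 nM to 150000 nM.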

Compound 4, half-maximal inhibitory concentration: > 40000 nM
Compound 4: a limit, no number; the forecaster's own chance of this, stated with the estimate: 25%; the middle value does not contradict the limit.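

In this assay compound 4 gives > 40000 nM, which is a limit of the assay and not a number. Even so, the step can be read as a lower bound: cyclopropyl in place of phenyl on an amide-type nitrogen in a ring gives an at least 2.2-fold higher number from compound 2 to compound 4 (0.35 log units; beyond the scatter), so the number rises on both cores, and the direction of the change carries over in this one further pair. Two pairs do not make a general rule, and the size of the change cannot be compared between the cores: the same change on two cores in this assay, a 3.9-fold higher number (0.60 log units; beyond the scatter) from compound 1 to compound 3 and an at least 2.2-fold higher number (0.35 log units; beyond the scatter) from compound 2 to compound 4; the limit leaves it open whether they differ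

Still open, from the compounds shown here alone, is how other groups on the amide-type nitrogen would behave on either core, for example methyl, a longer chain or a simple hydrogen. Also open, going by these compounds, is whether the same direction would hold on a third core, or with an amine or a carboxylic acid in place of the fluorine.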